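A few compounds are considered here, and "the series" means these few. Any claim that something is new, unique, unknown or untested is made for them only; others in the source may bear on it.

Measured compounds:
Compound 1, `Cc1nccn1-c1ccc(COc2cc(F)cc(C3(C(N)=O)CCOCC3)c2)cc1`: 340 nM
Compound 2, `COC1(c2cc(F)cc(OCc3ccc(-n4ccnc4C)cc3)c2)CCOCC1`: 60 nM

Both numbers come from an assay on blood for inhibition of Polyunsaturated fatty acid 5-lipoxygenase (Homo sapiens); on this read-out lower numbers stand for stronger inhibition and higher numbers for weaker inhibition. Of the two measured compounds, compound 2 gives the lower number, and the step of a 5.7-fold lower number from compound 1 to compound 2 (0.75 log units; beyond the scatter) lies beyond the usual scatter, so compound 2 stands as the stronger inhibitor of the pair.

Compound 3, `CCOC1(c2cc(F)cc(OCc3ccc(-n4ccnc4C)cc3)c2)CCOCC1`, is not yet measured. It differs from compound 2 in one place: methyl in place of hydrogen on a saturated chain carbon bound to an oxygen on a saturated carbon. Read one bond further out, this turns the methoxy group of compound 2 into an ethoxy group.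

For the measured compounds named here, no measured step bears directly on this change. Going by the values given here, the only step known, a 5.7-fold lower number from compound 1 to compound 2 (0.75 log units; beyond the scatter), exchanged a carbamoyl group for a methoxy group, which is a different kind of change and gives no guidance on going from methoxy to ethoxy. Without a comparable step, the plainest expectation is that compound 3 stays close to compound 2, with an expected step of no change at the digits printed from compound 2 to compound 3 (within the scatter) that does not exceed the scatter. Compound 3 is therefore estimated at 60 nM in this assay, with a range from 20 nM to 180 nM.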

Compound 3, half-maximal inhibitory concentration: 80 nM
For compound 3 the middle estimate is 1.3-fold (0.12 log units) below the measured one, within the range that was stated.
By their numbers in this assay, from the lowest: compounds 2 and 3 (each within the scatter of the next); then compound 1.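

In this assay, extending the methoxy group of compound 2 to the ethoxy group of compound 3 gives a 1.3-fold higher number from compound 2 to compound 3 (0.12 log units; within the scatter) and so the extra methyl on this saturated chain carbon bound to an oxygen makes no difference that can be told from assay scatter. Replacing the carbamoyl group of compound 1 with ethoxy gives a 4.3-fold lower number from compound 1 to compound 3 (0.63 log units; beyond the scatter) and this shows that the earlier difference between carbamoyl and methoxy is not unique to methoxy, since a second group of this kind also gives a number clearly lower than that of compound 1. No supporting data are available to explain either the lack of a clear change with the added methyl or the difference from the carbamoyl compound.

Going by these compounds, a single added methyl shows only the first step along this chain, so it remains open whether a longer chain such as propoxy, or a branched group such as isopropoxy, would stay within the scatter of compound 2. On these data alone, it is also open how a hydroxyl group or an amine on the same saturated ring carbon would compare with the methoxy and ethoxy groups.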